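This account rests on a few compounds, and the source may have more. Where it says the series, first, only, none or still open, it means among the compounds named here.

Measured so far:
compound 1 `Nc1nc(Cl)c2ncn([C@@H]3C[C@@]4(CO)CC[C@@H]3C4)c2n1` — 139000 nM in a functional assay on L1210 cells (Mus musculus), with a stated time of 48 h; on this read-out lower numbers stand for stronger inhibition and higher numbers for weaker inhibition
compound 2 `Nc1nc(N)c2ncn([C@@H]3C[C@@]4(CO)CC[C@@H]3C4)c2n1` — 179000 nM in this assay

Going by the values given here, compound 2 stands beside compound 1 on the two numbers in hand; the only step between them, a 1.3-fold higher number from compound 1 to compound 2 (0.11 log units; within the scatter), separates nothing. That step is amino in place of chloro on an aromatic carbon and says nothing about substitution on the exocyclic nitrogen.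

Compound 3 `Nc1nc(NC2CC2)c2ncn([C@@H]3C[C@@]4(CO)CC[C@@H]3C4)c2n1` carries cyclopropyl in place of hydrogen on a nitrogen on an aromatic ring. Among the compounds with values here, no measured step touches this nitrogen, so the change is uncharted; the one step known, from compound 1 to compound 2, is within the scatter and offers no direction. The working expectation for compound 3 is therefore a step not clearly beyond the scatter, with a wide range to allow for an unmeasured type of change. Compound 3 is expected at 120000 nM, range 30000 nM to 400000 nM. The step this estimate implies is a 1.5-fold lower number from compound 2 to compound 3 (0.17 log units; within the scatter), taken as an expectation only.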

Compound 3, half-maximal inhibitory concentration: 146000 nM
For compound 3 the middle estimate is 1.2-fold (0.09 log units) below the measured one, within the range that was stated.
By their numbers in this assay, from the lowest: compounds 1, 3 and 2 (each within the scatter of the next).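

Cyclopropyl in place of hydrogen on a nitrogen on an aromatic ring gives a 1.2-fold lower number from compound 2 to compound 3 (0.09 log units; within the scatter) in this assay, so this nitrogen, which the earlier step did not touch, takes the added ring with no change that stands clear of the scatter. Cyclopropylamino in place of chloro on an aromatic carbon gives a 1.1-fold higher number from compound 1 to compound 3 (0.02 log units; within the scatter), so chloro, amino and cyclopropylamino at this place all fall within the scatter of one another. Nothing measured here bears on a reason for this flat read-out.

From the compounds shown here alone, whether a benzyl group or a longer alkyl chain on this nitrogen would give a step beyond the scatter remains open. Also open, going by these compounds, is what a carboxylic acid would do in place of the hydroxymethyl shared by all three compounds.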